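The source may report more compounds than this note shows. Statements on the series, on what has been measured and on what is new or still open speak of the compounds shown alone.

Measured compounds:
- compound 1, `Cc1cn(C2CC(N=[N+]=[N-])C(COC(=O)OCCCC(=O)O)O2)c(=O)[nH]c1=O`, -0.55
- compound 2, `Cc1cn(C2CC(N=[N+]=[N-])C(COC(=O)OCCCC(=O)OC(C)(C)C)O2)c(=O)[nH]c1=O`, 1.14

Going by the values given here, in a physicochemical assay for lipophilicity (a lower number here means a more polar compound, a higher number a more lipophilic compound), compound 1 gives -0.55, the lowest of the two numbers measured so far; its nearest neighbour is compound 2, which lies a number 1.69 log units higher from compound 1 to compound 2 (beyond the scatter). That single step, tert-butyl in place of hydrogen on an oxygen next to a carbonyl group, is the only one measured, and it is large.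

Compound 3, `Cc1cn(C2CC(N=[N+]=[N-])C(COC(=O)CCCO)O2)c(=O)[nH]c1=O`, has not yet been measured in this assay. It differs from compound 1 in one place: 3-hydroxypropyl in place of 3-carboxypropoxy on a carbonyl carbon. Among the compounds with values here, compound 1 carries the free acid and compound 3 a hydroxyl on a shorter chain, and no measured step reproduces this change exactly. Within the data shown here, the step from compound 1 to compound 2 is the only guide: covering the acid hydrogen gave a number 1.69 log units higher from compound 1 to compound 2 (beyond the scatter). Removing the acid group altogether and leaving a hydroxyl is therefore expected to raise the number as well, though a hydroxyl remains, so a smaller rise than that step is expected, a number 0.85 log units higher from compound 1 to compound 3 (beyond the scatter). Compound 3 is estimated at 0.3, within a range of -0.3 to 0.9.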

Compound 3, partition coefficient: -0.95
Compound 3: middle estimate off by 1.25 log units, on the high side, and the stated range ends above it.
By their numbers in this assay, from the lowest: compound 3; then compound 1; then compound 2.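

Swapping 3-carboxypropoxy for 3-hydroxypropyl on this carbonyl carbon gives a number 0.40 log units lower from compound 1 to compound 3 (beyond the scatter) in this assay, so the free acid can go and the number can still fall. Set against a number 1.69 log units higher from compound 1 to compound 2 (beyond the scatter), where a tert-butyl group covers the acid hydrogen, this shows that removing that hydrogen does not by itself decide the direction of change: what takes its place matters, and the two changes at this position pull the number opposite ways. Nothing on hand explains why the number fell here.

From the compounds shown here alone, the step from compound 1 to compound 3 changes several things at once, since the carboxylic acid goes, a hydroxyl arrives, the group drops from 7 heavy atoms to 4, and the oxygen joining the chain to the carbonyl carbon is lost, so the share of each in the fall stays open. A 3-hydroxypropoxy group on the same carbonyl carbon would keep that oxygen and the chain while exchanging only the acid for a hydroxyl, and a longer chain ending in a hydroxyl or an amine would show how far the end group and the chain length each count.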